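Methoxy additions on the pendant ring of the shared core

The source may report more compounds than this note shows. Statements on the series, on what has been measured and on what is new or still open speak of the compounds shown alone.

Measured so far:
compound 1 `COc1ccc2c(c1)OC(N)=C(C#N)C2c1ccccc1`: 360000000 nM
compound 2 `COc1cccc(C2C(C#N)=C(N)Oc3cc(OC)ccc32)c1`: 52000000 nM

In a functional assay on T47D cells (Homo sapiens) for activation (on this read-out lower numbers stand for an effect already at smaller amounts and higher numbers for an effect only at larger amounts of compound), compound 1 gives 360000000 nM and compound 2 gives 52000000 nM. Compound 2 stands lowest of the two numbers, with compound 1 nearest. Compound 3 `COc1cc(OC)cc(C2C(C#N)=C(N)Oc3cc(OC)ccc32)c1` differs from compound 2 by methoxy in place of hydrogen on an aromatic carbon, meta to a methoxy group on the six-membered aromatic ring of carbon only. Going by the values given here, the single comparable step is a 6.9-fold lower number from compound 1 to compound 2 (0.84 log units; beyond the scatter). A repeat of that change on the same ring is expected to lower the number again in this assay, but less than before. Compound 3 is therefore estimated at 20000000 nM, within 5000000 nM to 60000000 nM, a step of a 2.6-fold lower number from compound 2 to compound 3 (0.41 log units; beyond the scatter).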

Compound 3, half-maximal effective concentration: 15000000 nM
Beside the measured number, compound 3's estimate is 1.3-fold (0.12 log units) above it, and the stated range covers the measured number.
By their numbers in this assay, from the lowest: compound 3; then compound 2; then compound 1.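

In this assay a second methoxy on the pendant ring, meta to a methoxy group, still lowers the number, with a 3.5-fold lower number from compound 2 to compound 3 (0.54 log units; beyond the scatter). Read alongside a 6.9-fold lower number from compound 1 to compound 2 (0.84 log units; beyond the scatter) the same change has now lowered the number twice on this ring, so the first step does not stand alone. Nothing on hand gives a reason for either step. Still open, on these data alone, is whether another group at this place, such as a hydroxyl, an amine or a longer alkoxy chain, moves the number the same way. Also open, as far as these compounds go, is whether a further methoxy on this ring lowers it again.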